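The compounds below may be only part of what the source reports. "The series", "measured", "known", "first", "only" and "open" are said of these compounds alone.

Of the compounds shown here, three have been measured. Compound 1 `O=C(CCSc1nc2cc(Cl)ccc2o1)N1CCS(=O)(=O)C1`, compound 2 `O=C(CCSc1nc(-c2ccccc2)co1)N1CCCC1` and compound 3 `CC(CC(=O)N1CCCC1)Sc1nc2cc(Cl)ccc2o1` were each tested in an ADME assay on microsomes from liver (Homo sapiens) for metabolic stability, read by LC-MS, using NADPH, with a stated time of 45 min, tested at 0.5 uM; on this read-out lower numbers stand for slow clearance and higher numbers for fast clearance. Compound 1 gives 1.7 mL/min/g, the lowest of the three numbers. Compound 3 gives 8.6 mL/min/g, and compound 2 gives 20.9 mL/min/g; both of these stand beyond the scatter above compound 1, so compound 1 is cleared most slowly among the three.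

The next compound, compound 4 `CCN(CC)C(=O)CCSc1nc2cc(Cl)ccc2o1`, is built from compound 1 by a single change: diethylamino in place of 1,1-dioxo-1,3-thiazolidin-3-yl on a carbonyl carbon. The ring that leaves carries two hydrogen-bond acceptors, while the diethylamino group that enters has none.

Going by the values given here, no step between measured compounds mirrors this change, so the expectation for compound 4 rests on the spread of the numbers seen so far. Compound 3 keeps the core of compound 1 but carries a different amide, and compound 3 gives 8.6 mL/min/g. Compound 4 is expected to move in the same direction, towards faster clearance. The step from compound 1 to compound 4 is estimated at a 5.3-fold higher number from compound 1 to compound 4 (0.72 log units; beyond the scatter). For compound 4 in this assay the estimated value is 9 mL/min/g, with a likely range from 3.5 mL/min/g to 23 mL/min/g.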

Compound 4, intrinsic clearance in a liver preparation (reported as CLH), per the amount of preparation that the assay uses: 5.9 mL/min/g
Compound 4: the middle estimate sits 1.5-fold (0.18 log units) above what was measured; measured number inside the range.
By their numbers in this assay, from the lowest: compound 1; then compounds 4 and 3 (each within the scatter of the next); then compound 2.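

In this assay, going by these compounds alone, diethylamino in place of 1,1-dioxo-1,3-thiazolidin-3-yl on a carbonyl carbon gives a 3.5-fold higher number from compound 1 to compound 4 (0.54 log units; beyond the scatter), the first reading of this position with the rest of the molecule unchanged. The step is modest but beyond the usual scatter, so changing this one group is enough to shift the clearance number. Nothing measured here accounts for the shift.

Within the data shown here, the single step swaps a ring carrying two hydrogen-bond acceptors for an open group with none, so it cannot separate the effect of the ring from that of the acceptors. Morpholine or the thiazolidine ring without its two oxygens, placed on the same carbonyl carbon, would be a way to pull these two features apart.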